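Series notes: bromo in place of methyl

A few compounds are considered here, and "the series" means these few. Any claim that something is new, unique, unknown or untested is made for them only; others in the source may bear on it.

Values in a functional assay on HeLa cells (Homo sapiens) for inhibition, read by MTT assay, with a stated time of 72 h; on this read-out higher numbers stand for weaker inhibition and lower numbers for stronger inhibition
compound 1 `Brc1ccc(-c2nnc(SCCCN3CCN(c4nc5ccccc5o4)CC3)o2)cc1` gives 187000 nM
compound 2 `Cc1ccc(-c2nnc(SCCCN3CCN(c4nc5ccccc5s4)CC3)o2)cc1` gives 179000 nM
compound 3 `Brc1ccc(-c2nnc(SCCCN3CCN(c4nc5ccccc5s4)CC3)o2)cc1` is not yet measured

Compound 2 gives 179000 nM in this assay and stands level, within the scatter, with compound 1, which gives 187000 nM in the same read-out. Compound 3 differs from compound 2 by bromo in place of methyl on an aromatic carbon in one place: bromo in place of methyl on an aromatic carbon, which reads one bond further out as 4-methylphenyl to 4-bromophenyl.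

Within the data shown here, no measured pair shows this change alone, so its size has no direct precedent. No step beyond the scatter is expected for it in this assay in either direction. Compound 1, which also carries a 4-bromophenyl, gives 187000 nM as its value, and compound 2, with its 4-methylphenyl, gives 179000 nM as its value, so both groups have been seen at this level. The estimated 1.0-fold higher number from compound 2 to compound 3 (0.00 log units; within the scatter) is expected to stay within the scatter. Compound 3 is estimated at 180000 nM with an expected range from 95000 nM to 340000 nM in this read-out.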

Compound 3, half-maximal inhibitory concentration: 243000 nM
The estimate for compound 3 lay 1.4-fold (0.13 log units) below the measured number, within the range that was stated.
By their numbers in this assay, from the lowest: compounds 2, 1 and 3 (each within the scatter of the next).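

In this assay, the change from 4-methylphenyl to 4-bromophenyl now has a direct pair: a 1.4-fold higher number from compound 2 to compound 3 (0.13 log units; within the scatter), so at this place, on a six-membered aromatic ring of carbon only and para to a large group, bromo and methyl cannot be told apart in this read-out. Compound 3 also gives the series a single-place reading of a second change, 1,3-benzothiazol-2-yl in place of 1,3-benzoxazol-2-yl on an amine nitrogen in a ring, with a 1.3-fold higher number from compound 1 to compound 3 (0.11 log units; within the scatter), so that change likewise shows no step beyond the scatter with 4-bromophenyl in place. No measurement is available that would explain either reading.

On these data alone, it remains open whether a group of another kind at this aromatic carbon, such as an amine, a carboxylic acid or a nitrile, would move the number beyond the scatter. Also open, as far as these compounds go, are whether the swap of 1,3-benzothiazol-2-yl for 1,3-benzoxazol-2-yl reads the same with 4-methylphenyl in place, and whether a longer chain on the sulfur would change the picture.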